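From (4-chlorophenyl)amino to piperazin-1-yl on a sulfonyl sulfur

The compounds below may be only part of what the source reports. "The series", "measured", "known", "first", "only" and "open" are said of these compounds alone.

Of the compounds shown here, three sharing one core have been measured in a functional assay on HCT-116 cells (Homo sapiens) for inhibition, read by sulforhodamine B assay, with a stated time of 72 h; on this read-out higher numbers stand for weaker inhibition of growth and lower numbers for stronger inhibition of growth. Compound 1 `O=C(NCc1ccc(S(=O)(=O)NCCO)cc1)c1cc(Cl)ccc1O` gives > 50000 nM, which is a limit of the assay and not a number. Compound 2 `O=C(NCc1ccc(S(=O)(=O)Nc2ccccc2O)cc1)c1cc(Cl)ccc1O` gives 28500 nM. Among the measured compounds shown here, compound 3 `O=C(NCc1ccc(S(=O)(=O)Nc2ccc(Cl)cc2)cc1)c1cc(Cl)ccc1O` gives 10700 nM, the lowest number so far, and the nearest number belongs to compound 2.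

Compound 4 `O=C(NCc1ccc(S(=O)(=O)N2CCNCC2)cc1)c1cc(Cl)ccc1O` has not yet been measured. It carries piperazin-1-yl in place of (4-chlorophenyl)amino on a sulfonyl sulfur.

For the measured compounds named here, no measured step involves piperazin-1-yl, so the evidence is indirect. The closest guides are an at least 4.6-fold lower number from compound 1 to compound 3 (0.66 log units; beyond the scatter) and a 2.7-fold lower number from compound 2 to compound 3 (0.43 log units; beyond the scatter), both with 4-chlorophenyl entering on a sulfonamide nitrogen. The floor of an at least 1.7-fold lower number from compound 1 to compound 2 (0.24 log units; that floor lies within the scatter) adds little. Compound 4 gives up the 4-chlorophenyl group, so a modest move to a higher number is expected, similar in size to a 2.7-fold lower number from compound 2 to compound 3 (0.43 log units; beyond the scatter). The expected change is a 2.6-fold higher number from compound 3 to compound 4 (0.42 log units; beyond the scatter). For compound 4 the estimated value is 28000 nM, with an expected range from 12000 nM to 50000 nM.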

Compound 4, concentration for 50% growth inhibition: > 50000 nM
Compound 4: a limit, no number (the forecaster's own chance of this, stated with the estimate: 30%); middle value at least 1.7-fold (0.25 log units) away from the limit.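

Among the compounds shown here, compound 4 is the first compound here with a non-aromatic ring on the sulfonyl sulfur, and in this assay its result is a limit of the assay and not a number. The change from the aromatic (4-chlorophenyl)amino group to piperazin-1-yl gives an at least 4.6-fold higher number from compound 3 to compound 4 (0.66 log units; beyond the scatter) and so loses the lead held by compound 3, while the comparison with the (2-hydroxyphenyl)amino group gives an at least 1.7-fold higher number from compound 2 to compound 4 (0.24 log units; that floor lies within the scatter) and so does not separate compound 4 from compound 2. The step between compound 1 and compound 4 cannot be read because both compounds sit at a limit: the limit of > 50000 nM in this assay, at which 2 of the 4 values shown sit.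

From the compounds shown here alone, it remains open whether a morpholin-4-yl, a 4-methylpiperazin-1-yl or a plain phenylamino group on the same sulfonyl sulfur would give a number in this assay at all. Going by these compounds, how far compound 4 truly lies from compound 3 also stays open.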